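The compounds below may be only part of what the source reports. "The series", "measured", "known", "first", "only" and "open" are said of these compounds alone.

Working notes on the series.

Three compounds of the shared core have numbers in an assay (Rattus norvegicus) for inhibition of Fatty-acid amide hydrolase 1 (Homo sapiens) (on this read-out lower numbers stand for stronger inhibition and higher numbers for weaker inhibition), so far. Compound 1, `COC(=O)c1ccccc1-c1cnc(C(=O)CCCCCCc2ccccc2)o1`, gives 60 nM in this assay. Compound 2, `NS(=O)(=O)c1ccccc1-c1cnc(C(=O)CCCCCCc2ccccc2)o1`, gives 1500 nM. Compound 3, `Nc1cccc(-c2cnc(C(=O)CCCCCCc3ccccc3)o2)c1`, gives 19 nM, the lowest of the three numbers in this assay; compound 1 stands nearest to it and compound 2 furthest.

For the measured compounds named here, the one step measured inside the series is a 25-fold higher number from compound 1 to compound 2 (1.40 log units; beyond the scatter), a change of the group carried on the aromatic ring while that ring itself stays. Going by the values given here, compound 1 and compound 3 differ in more than one place, so only their two values can be set side by side, and no single step is known between them.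

Compound 4, `COc1ccnc(-c2cnc(C(=O)CCCCCCc3ccccc3)o2)c1`, is still to be measured. Its change from compound 3 is 4-methoxypyridin-2-yl in place of 3-aminophenyl on an aromatic carbon. Among the compounds with values here, no measured step swaps the whole aromatic ring in this way, so the step from compound 1 to compound 2 bears on it only loosely, as a sign that changes at this position can move the number far. Compound 4 is therefore expected to sit somewhat weaker than compound 3, with a 2.6-fold higher number from compound 3 to compound 4 (0.42 log units; beyond the scatter) as the expected step. The estimate for compound 4 in this assay is 50 nM, with a range from 12 nM to 200 nM.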

Compound 4, inhibition constant: 0.8 nM
For compound 4 the middle estimate is 63-fold (1.80 log units) above the measured one; the whole stated range lies above it.
By their numbers in this assay, from the lowest: compound 4; then compound 3; then compound 1; then compound 2.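

For the compounds shown here, at this aromatic carbon, next to the ring oxygen, putting 4-methoxypyridin-2-yl in place of 3-aminophenyl gives a 24-fold lower number from compound 3 to compound 4 (1.38 log units; beyond the scatter) in this assay, so the whole aromatic ring can be exchanged here with a large move towards stronger inhibition, whereas the only earlier step, a 25-fold higher number from compound 1 to compound 2 (1.40 log units; beyond the scatter), ran towards weaker inhibition and kept the ring. The new step joins several changes in one: a ring of carbon only gives way to a ring with a hetero atom, the amine leaves, and a methoxy group enters, so its size cannot be divided among them. No measurement among the data bears on the origin of this step.

The compounds shown leave open whether the ring nitrogen, the methoxy group or the two together go with the lower number, a question that a phenyl ring carrying a methoxy group and a pyridine ring without one would separate. Also open, on these data alone, is how an amine, a carboxylic acid or an ethoxy group would read in place of the methoxy group on the same pyridine ring.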